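Pyridazine–pyrimidinylpiperazine series: ring substituent at the open position

A few compounds are considered here, and "the series" means these few. Any claim that something is new, unique, unknown or untested is made for them only; others in the source may bear on it.

Measured so far:
compound 1 `Cc1ccnnc1N1CCN(c2ncccn2)CC1` – > 100000 nM
compound 2 `Cc1cc(C(C)C)nnc1N1CCN(c2ncccn2)CC1` – > 100000 nM
compound 3 `Cc1ccc(-c2cc(C)c(N3CCN(c4ncccn4)CC3)nn2)cc1` – 17200 nM

In a functional assay on BV-2 cells (Mus musculus) for inhibition, read by ELISA, with a stated time of 16 h (on this read-out lower numbers stand for stronger inhibition and higher numbers for weaker inhibition), compound 1 gives only a limit, > 100000 nM, and no number. Compound 2 likewise gives only a limit in this assay, > 100000 nM, so the step that the two limits leave unreadable from compound 1 to compound 2 cannot be read. For the measured compounds named here, compound 3 is the one compound with a number, 17200 nM, and the step of an at least 5.8-fold lower number from compound 1 to compound 3 (0.76 log units; beyond the scatter) as well as an at least 5.8-fold lower number from compound 2 to compound 3 (0.76 log units; beyond the scatter) show that 4-methylphenyl in place of hydrogen or of isopropyl brings the number down out of the limit.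

The unmeasured compound 4 `Cc1cc(-c2cccnc2)nnc1N1CCN(c2ncccn2)CC1` differs from compound 1 as follows: pyridin-3-yl in place of hydrogen on an aromatic carbon. Like compound 3 it carries a six-membered aromatic ring at this carbon, so the step from compound 1 to compound 3 is the one that bears on it; compound 2 shows that a non-aromatic group there leaves the value at the limit (the limit of > 100000 nM in this assay, at which 2 of the 3 values shown sit). Compound 4 is therefore expected to move in the same direction as compound 3, by about an at least 2.8-fold lower number from compound 1 to compound 4 (0.45 log units; beyond the scatter), though the pyridin-3-yl ring may not carry the full gain. For compound 4 the estimate in this assay is 35000 nM, within 12000 nM to 100000 nM.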

Compound 4, half-maximal inhibitory concentration: > 100000 nM
Compound 4 gave a limit, no number; the forecaster's own chance of this, stated with the estimate: 30%; middle value at least 2.8-fold (0.45 log units) from the limit.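

In this assay, a six-membered aromatic ring at this carbon does not by itself bring the value off the limit: pyridin-3-yl and 4-methylphenyl are clearly separated, with an at least 5.8-fold higher number from compound 3 to compound 4 (0.76 log units; beyond the scatter). Among the groups shown, the gain therefore belongs to 4-methylphenyl alone, and compound 4 goes against any reading that extends it to aromatic rings at this position in general. The steps from compound 1 to compound 4 and from compound 2 to compound 4 cannot be read, and the series now sits mainly at one limit: the limit of > 100000 nM in this assay, at which 3 of the 4 values shown sit.

The compounds shown leave open whether the gain needs the methyl group on the phenyl ring or the all-carbon ring alone, a question that unsubstituted phenyl would address. As far as these compounds go, it is also open whether a phenyl ring carrying a methoxy group or a chlorine atom in place of that methyl group would keep the gain.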